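From 2-methylphenyl to 5-fluoro-2-methoxyphenyl on a shared core

The source may hold more compounds than are shown below. What is called first, only, known or untested is meant among the compounds shown, and "the series" means these compounds.

Of the compounds shown here, two built on a shared core have been measured so far: compound 1 `COc1ccc(-n2cnc3cnc(Oc4cccc(NC(C)=O)c4)cc32)cc1OC` and compound 2 `COc1ccc(-n2cnc3cnc(-c4ccccc4C)cc32)cc1OC`. In a physicochemical assay for solubility (a lower number here means a less soluble compound, a higher number a more soluble compound), compound 1 gives > 200000 nM, which is a limit of the assay and not a number. Compound 2 gives > 200000 nM, which is also only a limit. Among the measured compounds shown here, the whole record is therefore (the limit of > 200000 nM in this assay, at which 2 of the 2 values shown sit), so compound 2 has no exact value, and no step between measured compounds can be read.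

The next compound, compound 3 `COc1ccc(-n2cnc3cnc(-c4cc(F)ccc4OC)cc32)cc1OC`, keeps the core and changes one group, with 5-fluoro-2-methoxyphenyl in place of 2-methylphenyl on an aromatic carbon. For the measured compounds named here, with no measured step as a guide, only a small change is expected, either a slight drop or nothing beyond the scatter. The expected move in this assay is an at least 1.1-fold lower number from compound 2 to compound 3 (0.07 log units; that floor lies within the scatter). The estimate for compound 3 is 170000 nM, with an expected range of 70000 nM to 200000 nM. A reading that again reports only a limit is also quite likely.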

Compound 3, solubility: 9000 nM
For compound 3 the middle estimate is 19-fold (1.28 log units) above the measured one, outside the stated range (below it).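

With 5-fluoro-2-methoxyphenyl in place of 2-methylphenyl, on the aromatic carbon next to the ring nitrogen, this assay shows an at least 22-fold lower number from compound 2 to compound 3 (1.34 log units; beyond the scatter), which means that a change at this position can move the read-out by a large amount. Compound 3 gives 9000 nM, the only exact number among the compounds shown, and this gives later changes at the same place a real value to be compared with. The size of the step is only a lower bound, since its starting point is a limit of the assay and not a number: the limit of > 200000 nM in this assay, at which 2 of the 3 values shown sit.

The change brings in a methoxy group and a fluorine together, so the compounds shown cannot tell which of the two goes with the drop, or whether either one alone would give it. Among the compounds shown here, whether an amine or a carboxylic acid on this phenyl ring would bring the number back up to the limit also stays open, and no other step between these compounds can be read.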